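Swapping the Amide Ring for a Chloropyridine

The source may report more compounds than this note shows. Statements on the series, on what has been measured and on what is new or still open speak of the compounds shown alone.

Two measured compounds share one core and differ only in the ring attached to the amide carbonyl. Compound 1 `COc1ccc(C(=O)Nc2cccc(-c3oc4cc(-c5ccc(F)cc5)ccc4c(=O)c3O)c2)cc1` carries a 4-methoxyphenyl there, and in a functional assay on HepG2 cells (Homo sapiens) for antiproliferative activity, read by CCK-8 assay, with a stated time of 72 h (a higher number here means a weaker inhibitor, a lower number a stronger inhibitor), compound 1 gives 8420 nM. Compound 2 `Cc1cc(C(=O)Nc2cccc(-c3oc4cc(-c5ccc(F)cc5)ccc4c(=O)c3O)c2)ccc1F` carries a 4-fluoro-3-methylphenyl instead; in this assay compound 2 gives 9540 nM, so the two numbers sit within the scatter of each other, the step being a 1.1-fold higher number from compound 1 to compound 2 (0.05 log units; within the scatter). Compound 3 `O=C(Nc1cccc(-c2oc3cc(-c4ccc(F)cc4)ccc3c(=O)c2O)c1)c1ccc(Cl)nc1` is not yet measured; it differs from compound 2 by 6-chloropyridin-3-yl in place of 4-fluoro-3-methylphenyl on a carbonyl carbon. For the measured compounds named here, the only measured step that bears on this change, a 1.1-fold higher number from compound 1 to compound 2 (0.05 log units; within the scatter), also exchanged one ring at the same place and barely moved the number. A step within the scatter is therefore expected in this assay, with no clear direction. For compound 3 the estimate is 9000 nM, within a range from 4000 nM to 20000 nM. For compound 3 this estimate means an expected step of a 1.1-fold lower number from compound 2 to compound 3 (0.03 log units; within the scatter).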

Compound 3, half-maximal inhibitory concentration: 4610 nM
Estimate against measurement, compound 3: 2.0-fold (0.29 log units) above; measured number inside the range.
By their numbers in this assay, from the lowest: compounds 3, 1 and 2 (each within the scatter of the next, the first and the last beyond it).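

For the compounds shown here, this position on the carbonyl carbon can move the number in this assay: there is a 2.1-fold lower number from compound 2 to compound 3 (0.32 log units; beyond the scatter) and this is the first step here to pass the usual scatter, though only modestly. Going by these compounds alone, the comparison with the 4-methoxyphenyl ring of compound 1 gives a 1.8-fold lower number from compound 1 to compound 3 (0.26 log units; within the scatter) and stays within the scatter, so 6-chloropyridin-3-yl shows a clear advantage over only one of the two rings it can be compared with. No measurement shown explains the shift.

The ring nitrogen and the chlorine enter together, so the compounds shown cannot separate their contributions; a plain pyridin-3-yl or a 4-chlorophenyl ring would be needed to do that. As far as these compounds go, whether an amine or a carboxylic acid on this ring would move the number further also remains open.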